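Swapping carbamoyl for nitro on a poorly soluble compound

The source may report more compounds than this note shows. Statements on the series, on what has been measured and on what is new or still open speak of the compounds shown alone.

In a physicochemical assay for solubility, with a stated time of 4 h, at pH 2.0 (on this read-out higher numbers stand for higher solubility and lower numbers for lower solubility), compound 1 (`Cc1cc(/C=C/C#N)cc(C)c1Oc1cc(Nc2ccc(C#N)cc2)c(N)cc1C(N)=O`) gives 2.09 ug/mL. Within the data shown here, that is the lower of the two numbers available so far, as compound 2 (`CNC(=O)c1cc(N)c(Nc2ccc(C#N)cc2)cc1Oc1c(C)cc(CCC#N)cc1C`) gives 44.7 ug/mL, a gap well beyond the usual scatter. These two compounds differ in more than one place, so their gap cannot be tied to any single group. Compound 3 (`Cc1cc(/C=C/C#N)cc(C)c1Oc1cc(Nc2ccc(C#N)cc2)c(N)cc1[N+](=O)[O-]`) keeps the core of compound 1 and changes one thing: nitro in place of carbamoyl on an aromatic carbon. Among the measured compounds shown here, no measured pair shows this swap, so what follows is a judgement and not a reading. A modest drop in this assay is expected, close to the edge of the scatter, with an estimated 2.3-fold lower number from compound 1 to compound 3 (0.37 log units; beyond the scatter). For compound 3 the expected value is 0.9 ug/mL, within an estimated range from 0.2 ug/mL to 3.5 ug/mL.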

Compound 3, solubility: 0.29 ug/mL
The estimate for compound 3 lay 3.1-fold (0.49 log units) above the measured number; low and high end bracket the measured number.
By their numbers in this assay, from the lowest: compound 3; then compound 1; then compound 2.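

In this assay, among these compounds, nitro in place of carbamoyl on this aromatic carbon, para to a (4-cyanophenyl)amino group, gives a 7.2-fold lower number from compound 1 to compound 3 (0.86 log units; beyond the scatter), and this is the first gap here that can be tied to a single change, with the rest of the structure held fixed. The two groups each hold 3 heavy atoms, while carbamoyl has 1 hydrogen-bond donor and nitro has 0 hydrogen-bond donors. Nothing measured here accounts for the lower number.

On these data alone, it remains open how other groups on this same carbon, such as a carboxylic acid, an amine or a longer chain ending in an amide, would read out in this assay. As far as these compounds go, it is also open whether this swap gives a step of similar size on a core different from the one shared here.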